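This account rests on a few compounds, and the source may have more. Where it says the series, first, only, none or still open, it means among the compounds named here.

Of the compounds shown here, three sharing one core have been read in a physicochemical assay for solubility, read by HPLC, in simulated intestinal fluid, with a stated time of 16 h, tested at 125 ug/mL; on this read-out higher numbers stand for higher solubility and lower numbers for lower solubility. Compound 1 (`CNC(=O)c1cc(C(=O)NC2CC2)cn([C@H](C)c2ccccc2)c1=O`) gives 815 ug/mL, compound 2 (`CNC(=O)c1cc(C(=O)NC2CCC2)cn(Cc2ccccn2)c1=O`) gives 920 ug/mL, and compound 3 (`CNC(=O)c1cc(C(=O)NC2CC2)cn(Cc2cccc([C@@H](C)O)c2)c1=O`) gives 495 ug/mL. Compound 3 lies within the scatter of both other compounds, so the three cannot be separated on these numbers. Compound 4 (`CNC(=O)c1cc(C(=O)NC2CC2)cn(Cc2cccc3c2CCN3)c1=O`) differs from compound 3 by carrying 2,3-dihydro-1H-indol-4-yl in place of 3-(1-hydroxyethyl)phenyl on a saturated chain carbon bound to an aromatic nitrogen. Among the compounds with values here, no two measured compounds differ in one place only, so no measured step is available as a guide. The closest reference is compound 3 at 495 ug/mL, and no shift beyond the scatter is expected in this assay, in either direction. The estimated change is small, a 1.1-fold lower number from compound 3 to compound 4 (0.04 log units; within the scatter). For compound 4 the estimated value is 450 ug/mL, with an expected range from 200 ug/mL to 900 ug/mL.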

Compound 4, solubility: 100 ug/mL
Compound 4: middle estimate off by 4.5-fold (0.65 log units), on the high side; measured number outside the range, below it.
By their numbers in this assay, from the lowest: compound 4; then compounds 3, 1 and 2 (each within the scatter of the next).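

In this assay, within the data shown here, the change at this position, on a saturated chain carbon bound to an aromatic nitrogen, gives a 5.0-fold lower number from compound 3 to compound 4 (0.69 log units; beyond the scatter), and this is the only one-place comparison available. It shows that this position can move the read-out even when the leaving and entering groups match in heavy-atom count and in hydrogen-bond donors and acceptors; the two groups differ in that 2,3-dihydro-1H-indol-4-yl has a five-membered non-aromatic ring and a nitrogen, and lacks the oxygen and defined stereocentre of 3-(1-hydroxyethyl)phenyl. No measurement available here accounts for the drop.

This single step cannot separate the effect of the added ring from that of exchanging oxygen for nitrogen. Going by these compounds, a 3-(1-aminoethyl)phenyl group, with an open-chain amine at this position, would bear on that question, and how far the step carries over to other amides on the shared core also remains open.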